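Swapping benzyl for 4-fluorophenyl: expected solubility of compound 4

The source may hold more compounds than are shown below. What is called first, only, known or untested is meant among the compounds shown, and "the series" means these compounds.

Compound 1 `COc1cccc(CNCCCNc2ccnc3cc(Cc4ccccc4)ccc23)c1O` belongs to a small set of three related compounds that have been tested in a physicochemical assay for solubility, with a stated time of 18 h, at pH 7.4; a higher number here means a more soluble compound, a lower number a less soluble compound. In this assay compound 1 gives 4200 nM. Compound 2 `COc1ccc(F)cc1CNCCCNc1ccnc2cc(Cc3ccc(F)cc3Cl)ccc12` gives 4200 nM, and compound 3 `COc1ccc(F)cc1CNCCCNc1ccnc2cc(Cc3ccccc3)ccc12` gives 4200 nM, so compound 1 stands level with both of its neighbours at the digits shown. The step of no change at the digits printed from compound 1 to compound 3 (within the scatter) and the step of no change at the digits printed from compound 2 to compound 3 (within the scatter) both stay within the usual scatter of the measurement.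

Compound 4 `COc1cccc(CNCCCNc2ccnc3cc(-c4ccc(F)cc4)ccc23)c1O` differs from compound 1 in a single place: 4-fluorophenyl in place of benzyl on an aromatic carbon. Neither measured step touches this position. The change from compound 1 to compound 3 alters the group on the chain carbon bound to the amine nitrogen, and the change from compound 2 to compound 3 alters the group carried by the saturated chain carbon, not the attachment itself. Going by the values given here, no measured step therefore bears directly on the move to compound 4; the three values only show a set that does not shift with changes at either end of the shared core. Without a direct precedent, I expect at most a small step, a 1.4-fold lower number from compound 1 to compound 4 (0.15 log units; within the scatter), and I give it a wide range. For compound 4 the estimate in this assay is 3000 nM, between 1000 nM and 8000 nM.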

Compound 4, solubility: 32000 nM
Estimate against measurement, compound 4: 11-fold (1.03 log units) below, and the stated range ends below it.
By their numbers in this assay, from the lowest: compounds 1, 2 and 3 (each within the scatter of the next); then compound 4.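

In this assay, going by these compounds alone, this position responds where the earlier changes did not: replacing benzyl with 4-fluorophenyl on the aromatic carbon gives a 7.6-fold higher number from compound 1 to compound 4 (0.88 log units; beyond the scatter), the first step in the set beyond the scatter. The earlier step at this same site, no change at the digits printed from compound 2 to compound 3 (within the scatter), changed only the groups on the ring and kept the saturated chain carbon that links it to the core, so the ring's substituents alone gave no sign of this sensitivity. The new swap removes that saturated carbon and places the ring on the aromatic carbon, while also bringing in a fluorine, but no measurement here gives a reason for the rise.

The compounds shown leave open which of these two differences carries the step, since plain phenyl or 4-fluorobenzyl in this place would be needed to separate the loss of the linking carbon from the presence of the fluorine. They also leave open whether the same swap holds on the core of compound 3, with 5-fluoro-2-methoxyphenyl at the other end, and how a ring bearing an amine or a carboxylic acid would behave at this position.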